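Aryl Variation and Expected Inhibition of Compound 4

The source may hold more compounds than are shown below. What is called first, only, known or untested is meant among the compounds shown, and "the series" means these compounds.

Measured compounds, each in a functional assay on LOX IMVI cells (Homo sapiens) for inhibition, read by sulforhodamine B assay, with a stated time of 48 h, tested at 10 uM; a higher number here means more inhibition at the concentration tested (going by the name of the read-out), a lower number less inhibition:
- compound 1, `c1ccc(-c2cn3ccnc3c(-c3ccc4ncn(C5CCCCC5)c4c3)n2)cc1`, compound 1 gives 39.6%
- compound 2, `c1cn2cc(-c3ccsc3)nc(-c3ccc4ncn(C5CCCCC5)c4c3)c2n1`, compound 2 gives 4.9%
- compound 3, `Clc1ccc(-c2cn3ccnc3c(-c3ccc4ncn(C5CCCCC5)c4c3)n2)cc1`, compound 3 gives 14.8%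

Compound 3 stands second highest of the three numbers; its nearest neighbour is compound 2, and the gap between them lies within the scatter, while compound 1 sits beyond the scatter above it, as the step of a number 24.8 percentage points lower from compound 1 to compound 3 (beyond the scatter) shows. Compound 4, `FC(F)(F)c1cccc(-c2cn3ccnc3c(-c3ccc4ncn(C5CCCCC5)c4c3)n2)c1`, has not yet been measured. Its change from compound 3 is 3-(trifluoromethyl)phenyl in place of 4-chlorophenyl on an aromatic carbon. Among the measured compounds shown here, two measured steps bear on it: the step of a number 24.8 percentage points lower from compound 1 to compound 3 (beyond the scatter) shows that a chloro on the phenyl lowered inhibition, and the step of a number 9.9 percentage points higher from compound 2 to compound 3 (within the scatter) shows that exchanging one aryl group for another shifted the number only within the scatter. For the measured compounds named here, the single substituted-phenyl example gives no clear direction for a trifluoromethyl group, so the step of a number 5.2 percentage points higher from compound 3 to compound 4 (within the scatter) is expected to stay within the scatter, with a wide range. Compound 4 is therefore estimated at 20%, between 2% and 42%.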

Compound 4, a percentage reported as inhibition, at one concentration (the size of the read-out at that concentration, not a potency): 3.45%
Estimate against measurement, compound 4: 16.6 percentage points above; measured number inside the range.
By their numbers in this assay, from the lowest: compounds 4, 2 and 3 (each within the scatter of the next, the first and the last beyond it); then compound 1.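

In this assay, a trifluoromethyl group on the phenyl also lowers inhibition, with a number 36.2 percentage points lower from compound 1 to compound 4 (beyond the scatter), so both substituted phenyl compounds now lie beyond the scatter under the plain phenyl of compound 1. The two substituted phenyl groups are not interchangeable at this position, as a number 11.4 percentage points lower from compound 3 to compound 4 (beyond the scatter) separates them, whereas a number 1.5 percentage points lower from compound 2 to compound 4 (within the scatter) leaves the 3-(trifluoromethyl)phenyl and the thiophen-3-yl level with each other. Nothing available here explains why these groups differ.

Compound 3 and compound 4 differ both in the substituent and in where it sits on the phenyl, so the compounds shown cannot separate these two changes. Going by these compounds, it also stays open whether an amine, a methoxy group or a carboxylic acid on the phenyl would keep the inhibition of compound 1.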